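A few compounds are considered here, and "the series" means these few. Any claim that something is new, unique, unknown or untested is made for them only; others in the source may bear on it.

Measured compounds:
compound 1, `[N-]=[N+]=NCC(O)Cn1c(=O)n(C2OC(CO)[C@@H](O)[C@H]2O)c2nc(N)nc(O)c21`, 39 uM in a functional assay (B cells) with Mus musculus as the target; on this read-out higher numbers stand for an effect only at larger amounts of compound and lower numbers for an effect already at smaller amounts
compound 2, `C=CCn1c(=O)n(C2C=CC(CO)O2)c2nc(N)nc(O)c21`, 6 uM in this assay

Within the data shown here, of the two numbers known, compound 1 gives the higher one in this assay, and compound 2 gives the lower one; no step between them is worked out here, so only their two values are spoken of. The account turns to compound 3, `Cn1c(=O)n(C2OC(CO)[C@@H](O)[C@H]2O)c2nc(N)nc(O)c21`, which is not yet measured and differs from compound 1 by hydrogen in place of 2-azido-1-hydroxyethyl on a saturated chain carbon bound to an aromatic nitrogen. Among the measured compounds shown here, no step between measured compounds covers this change, so the size of the step is open; the step expected from compound 1 to compound 3 is a 1.0-fold higher number from compound 1 to compound 3 (0.01 log units; within the scatter), with no direction beyond the scatter. For compound 3 the estimate in this assay is 40 uM, ranging from 12 uM to 130 uM.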

Compound 3, concentration for half-maximal effect: 10 uM
Beside the measured number, compound 3's estimate is 4.0-fold (0.60 log units) above it; measured number outside the range, below it.
By their numbers in this assay, from the lowest: compounds 2 and 3 (each within the scatter of the next); then compound 1.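

Putting hydrogen in place of 2-azido-1-hydroxyethyl, on a saturated chain carbon bound to an aromatic nitrogen, gives a 3.9-fold lower number from compound 1 to compound 3 (0.59 log units; beyond the scatter) in this assay. This position therefore responds to change on this read-out, and the full 3-azido-2-hydroxypropyl chain is not required for an effect, since the methyl compound acts at smaller amounts. No available evidence bears on the reason for this step.

Whether the azide or the hydroxyl accounts for the difference remains open. So does how an amine, a carboxylic acid or a plain propyl chain would read at this place.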